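Solubility notes: cyclohexyl in place of 3,5-dimethylphenyl

This account rests on a few compounds, and the source may have more. Where it says the series, first, only, none or still open, it means among the compounds named here.

Measured compounds:
compound 1 `COc1ccc(F)cc1CNCCCNc1ccnc2cc(Cc3cc(C)cc(C)c3)ccc12`: 4200 nM
compound 2 `Cc1cc(C)cc(Cc2ccc3c(NCCCNCc4ccco4)ccnc3c2)c1`: 4200 nM
compound 3 `COc1cccc(CNCCCNc2ccnc3cc(Oc4cccc(N(C)C)c4)ccc23)c1O`: 14500 nM

In a physicochemical assay for solubility, with a stated time of 18 h, at pH 7.4 (a lower number here means a less soluble compound, a higher number a more soluble compound), compound 1 stands level with compound 2, and the two together give the lowest numbers of the three; compound 3 lies furthest from compound 1, beyond the scatter. Among the compounds with values here, the only single-place step measured so far, no change at the digits printed from compound 1 to compound 2 (within the scatter), alters the group on a saturated chain carbon bound to an amine nitrogen and leaves the read-out unchanged. Compound 3 differs from compound 1 in more than one place, so its higher number cannot be assigned to any single change.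

Compound 4 `COc1ccc(F)cc1CNCCCNc1ccnc2cc(CC3CCCCC3)ccc12` is not yet measured. It differs from compound 1 in this way: cyclohexyl in place of 3,5-dimethylphenyl on a saturated chain carbon bound to an aromatic carbon. Within the data shown here, no measured pair alters a group at this position, so nothing bears directly on the change; the one step available, no change at the digits printed from compound 1 to compound 2 (within the scatter), concerns a different part of the molecule and showed no movement. With no evidence either way, the expected step is a 1.2-fold higher number from compound 1 to compound 4 (0.08 log units; within the scatter), which is within the scatter. Compound 4 is estimated at 5000 nM, with a range from 2000 nM to 12000 nM.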

Compound 4, solubility: 4200 nM
Compound 4: middle estimate off by 1.2-fold (0.08 log units), on the high side, and the stated range covers the measured number.
By their numbers in this assay, from the lowest: compounds 1, 2 and 4 (each within the scatter of the next); then compound 3.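

In this assay this position now has a measured step of its own: the change on a saturated chain carbon bound to an aromatic carbon gives no change at the digits printed from compound 1 to compound 4 (within the scatter) and so adds a second single-place step to the series. Here the six-membered aromatic ring of 3,5-dimethylphenyl gives way to the six-membered non-aromatic ring of cyclohexyl, with 8 heavy atoms leaving and 6 entering, and this one pair shows no movement in the read-out. No measurement here accounts for that outcome, so it stands as an observation for this pair on the core of compound 1 only.

On these data alone, both groups at this position are rings of carbon only with no hydrogen-bond donors or acceptors, so it remains open whether a group carrying an amine or a carboxylic acid, such as piperidin-4-yl or 4-carboxyphenyl, would also leave the read-out in place. As far as these compounds go, it is equally open whether the same change from 3,5-dimethylbenzyl to cyclohexylmethyl would hold on compound 2, with its furan-2-yl group, or with a longer chain in place of the single saturated carbon.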